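Swapping the Piperidine Side Group of a Tryptamine Series

A few compounds are considered here, and "the series" means these few. Any claim that something is new, unique, unknown or untested is made for them only; others in the source may bear on it.

Measured so far:
- Compound 1, `CN(C1CCN(CCCc2c[nH]c3ccc(-n4cnnc4)cc23)CC1)S(=O)(=O)c1ccccc1`: 1.5 nM
- Compound 2, `C[C@H](NCC1CCN(CCCc2c[nH]c3ccc(-n4cnnc4)cc23)CC1)c1ccccc1`: 4.4 nM

Going by the values given here, in an assay on CHO cells for displacement of a labelled ligand from 5-hydroxytryptamine receptor 1D (Homo sapiens) (on this read-out lower numbers stand for stronger inhibition and higher numbers for weaker inhibition), compound 2 gives the higher of the two numbers; the only other compound, compound 1, gives a lower number by a 2.9-fold higher number from compound 1 to compound 2 (0.47 log units; beyond the scatter), a change described as modest.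

The next compound, compound 3, has the structure `CC(C)=CCN(C)C1CCN(CCCc2c[nH]c3ccc(-n4cnnc4)cc23)CC1`. It differs from compound 2 by methyl(3-methylbut-2-en-1-yl)amino in place of ((1-phenylethyl)amino)methyl on a saturated ring carbon. Among the compounds with values here, only the single step from compound 1 to compound 2 bears on this change, and it involved the same ring position; that step, a 2.9-fold higher number from compound 1 to compound 2 (0.47 log units; beyond the scatter), shows that swapping the whole group there shifts the number moderately. Since the incoming group is smaller and has no ring, the number for compound 3 is expected to stay close to that of compound 2 or rise slightly, a step of roughly a 1.4-fold higher number from compound 2 to compound 3 (0.13 log units; within the scatter). The estimate for compound 3 in this assay is 6 nM, with a range from 1.5 nM to 25 nM.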

Compound 3, half-maximal inhibitory concentration: 0.5 nM
The estimate for compound 3 lay 12-fold (1.08 log units) above the measured number; the measured number lies below the stated range.
By their numbers in this assay, from the lowest: compound 3; then compound 1; then compound 2.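

In this assay, the change to methyl(3-methylbut-2-en-1-yl)amino on this saturated ring carbon gives a clear gain (an 8.8-fold lower number from compound 2 to compound 3 (0.94 log units; beyond the scatter)). Compounds 1 and 2 both carry a six-membered aromatic ring of carbon in this group, whereas compound 3 has no ring there, so among these compounds such a ring is not needed for a low number, and 3-methylbut-2-en-1-yl in place of phenylsulfonyl on the amine nitrogen also lowers it (a 3.0-fold lower number from compound 1 to compound 3 (0.48 log units; beyond the scatter)). No supporting data explain either gain.

From the compounds shown here alone, each step replaces several features at once, so the part of the new group that matters remains open. A saturated 3-methylbutyl chain on the same amine nitrogen would show whether the double bond counts, and a benzyl group would test a ring in that place.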